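The source may hold more compounds than are shown below. What is called first, only, known or untested is meant among the compounds shown, and "the series" means these compounds.

For the measured compounds named here, compound 1 `CC(c1ccc(-c2ccccc2)c(F)c1)c1nnc2n1N=C(c1ccc(C(F)(F)F)cc1)CS2` stands with the lower of the two numbers measured so far: in a functional assay on Huh-7 cells (Homo sapiens) for inhibition, read by sulforhodamine B assay, with a stated time of 72 h (a higher number here means a weaker inhibitor, a lower number a stronger inhibitor), compound 1 gives 9400 nM, while compound 2 `CC(c1ccc(-c2ccccc2)c(F)c1)c1n[nH]c(=S)n1N` gives 43100 nM, a gap that lies beyond the usual scatter. Compound 3 `CC(c1ccc(-c2ccccc2)c(F)c1)c1nnc2n1N=C(c1ccc([N+](=O)[O-])cc1)CS2` differs from compound 1 in one place, (nitro in place of trifluoromethyl on an aromatic carbon), a nitro in place of trifluoromethyl on an aromatic carbon. Going by the values given here, no measured pair shows this change; the expected 1.3-fold lower number from compound 1 to compound 3 (0.13 log units; within the scatter) is small, probably within the scatter, leaning if anything toward a lower number. Compound 3 is therefore expected to give about 7000 nM, within a range of 2500 nM to 20000 nM.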

Compound 3, half-maximal inhibitory concentration: 4300 nM
Compound 3: the middle estimate sits 1.6-fold (0.21 log units) above what was measured, within the range that was stated.
By their numbers in this assay, from the lowest: compound 3; then compound 1; then compound 2.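

Until now this position had carried only trifluoromethyl, so nothing showed whether the group on the aromatic carbon para to a large group matters. In this assay, nitro in its place gives a 2.2-fold lower number from compound 1 to compound 3 (0.34 log units; beyond the scatter), a modest step beyond the scatter, so the number does respond to a change at this position. No measurement here accounts for the step. As far as these compounds go, how a nitrile, an amine, a carboxylic acid or a lone chlorine would fare at this position remains open, as does whether the step would hold on another core.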